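The source may hold more compounds than are shown below. What is called first, only, known or untested is meant among the compounds shown, and "the series" means these compounds.

Compound 1 `CC(C)n1cnc2c(N)ncnc21`: 4300 nM
Compound 2 `Nc1ncnc2ncn(CCCO)c12`: > 100000 nM, which is a limit of the assay and not a number.
Compound 3 `Nc1ncnc2c1nc(Br)n2CCCO`: 1000 nM

These three compounds were tested in an assay on CHO cells for displacement of a labelled ligand from adenosine receptor A1 (Homo sapiens); a higher number here means a weaker inhibitor, a lower number a stronger inhibitor. Among the two numbers shown, compound 3 gives the lowest; compound 1 sits higher, and that gap lies beyond the scatter. Compound 4 `CC(O)Cn1c(Br)nc2c(N)ncnc21` has the same atoms as compound 3, joined differently: 1-hydroxyethyl in place of 2-hydroxyethyl on a saturated chain carbon bound to an aromatic nitrogen. Within the data shown here, no measured pair shows this kind of change, so no step can be read from the data. Such a change is expected to move the number little, if at all beyond the scatter, and the step from compound 3 to compound 4 is estimated at a 1.5-fold higher number from compound 3 to compound 4 (0.18 log units; within the scatter). Compound 4 is therefore expected at 1500 nM, with a range from 500 nM to 5000 nM.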

Compound 4, inhibition constant: 2900 nM
The estimate for compound 4 lay 1.9-fold (0.29 log units) below the measured number; the measured number falls inside the stated range.
By their numbers in this assay, from the lowest: compound 3; then compounds 4 and 1 (each within the scatter of the next). At a limit, above all of these: compound 2.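

In this assay, among these compounds, 1-hydroxyethyl in place of 2-hydroxyethyl on a saturated chain carbon bound to an aromatic nitrogen gives a 2.9-fold higher number from compound 3 to compound 4 (0.46 log units; beyond the scatter) and so shows something no earlier pair could: with no atom added or removed, how the chain's atoms are joined can alone move the number beyond the scatter. Nothing measured here accounts for this step.

Still open, as far as these compounds go, is how an amine or a carboxylic acid in place of the hydroxyl, or a longer chain, would fare at this position.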